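A few compounds are considered here, and "the series" means these few. Any claim that something is new, unique, unknown or untested is made for them only; others in the source may bear on it.

Compound 1 `CNC(=O)c1cc(Oc2ccc(NC(=O)c3cc4cccnc4n(-c4ccccc4)c3=O)cc2)ccn1` is tested in a functional assay on U-87MG ATCC cells for antiproliferative activity against U-87 MG (Homo sapiens), read by MTT assay, with a stated time of 72 h (a lower number here means a stronger inhibitor, a higher number a weaker inhibitor), where compound 1 gives 1820 nM, the lowest of the two numbers available; its closest neighbour is compound 2 `CNC(=O)c1cc(Oc2ccc(NC(=O)c3cc4cccnc4n(-c4ccc(F)cc4)c3=O)cc2)ccn1`, for which compound 2 gives 2910 nM. For the measured compounds named here, the one step that links them, a 1.6-fold higher number from compound 1 to compound 2 (0.20 log units; within the scatter), stays within the scatter. Compound 3 `CNC(=O)c1cc(Oc2ccc(NC(=O)c3cc4cccnc4n(-c4ccc(Cl)cc4)c3=O)cc2)ccn1` stands in this assay as "not determined" (no result reported), so compound 3 carries no number here. Compound 4 `CCCNC(=O)c1cc(Oc2ccc(NC(=O)c3cc4cccnc4n(-c4ccccc4)c3=O)cc2)ccn1` differs from compound 1 by ethyl in place of hydrogen on a saturated chain carbon bound to an amide-type nitrogen, the same difference read one bond further out as methylcarbamoyl to propylcarbamoyl. Going by the values given here, no measured step touches that part of the shared core, so the single step of a 1.6-fold higher number from compound 1 to compound 2 (0.20 log units; within the scatter) gives only a sense of how little a small change elsewhere moved the number. Compound 4 is therefore expected to sit near compound 1, with a 1.4-fold higher number from compound 1 to compound 4 (0.14 log units; within the scatter) as the estimated step, giving an estimate of 2500 nM within a range of 800 nM to 8000 nM.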

Compound 4, half-maximal inhibitory concentration: 1510 nM
Compound 4: middle estimate off by 1.7-fold (0.22 log units), on the high side, within the range that was stated.
By their numbers in this assay, from the lowest: compounds 4, 1 and 2 (each within the scatter of the next).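

Methylcarbamoyl to propylcarbamoyl is the first change shown at this end of the molecule, and in this assay it gives a 1.2-fold lower number from compound 1 to compound 4 (0.08 log units; within the scatter). Adding ethyl in place of hydrogen on this saturated chain carbon therefore leaves the number indistinguishable from that of the shorter chain. No measurement available here offers an explanation for this result.

Going by these compounds, whether a much longer chain, or a chain ending in an amine or a carboxylic acid, would also leave the number unchanged stays open. A single step cannot show how far this position tolerates change.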